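The compounds below may be only part of what the source reports. "The series", "measured", "known", "first", "only" and "open" are said of these compounds alone.

Measured compounds in an ADME assay on microsomes from liver (Homo sapiens) for metabolic stability; on this read-out higher numbers stand for a longer-lived compound and lower numbers for a shorter-lived compound:
- compound 1, `CCCNC(=O)C1CCN(C(=O)c2cc3sc(-c4ccccc4F)cc3n2Cc2ccc(OC)cc2)CC1`, gives 0.592 h
- compound 2, `CCCNC(=O)C1CCN(C(=O)c2cc3[nH]cnc3n2Cc2ccc(OC)cc2)CC1`, gives 1.27 h
- compound 3, `CCCCC(=O)C1CCN(C(=O)c2cc3sccc3n2Cc2ccc(OC)cc2)CC1`, gives 0.105 h

Among these three numbers compound 1 stands second highest. Compound 2 sits above it, and that gap lies beyond the usual scatter of repeated measurements. Compound 3 sits well below compound 1, and that gap too lies beyond the scatter. The three compounds share the same core and the same methoxybenzyl group; they differ in the ring fused to that core and in the chain on the far end.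

The step that is followed here leads from compound 1 to compound 4, `CCCNC(=O)C1CCN(C(=O)c2cc3sc(-c4ccccc4)cc3n2Cc2ccc(OC)cc2)CC1`, which has not yet been measured in this assay. The change is small: hydrogen in place of fluoro on an aromatic carbon. Cut one bond further out, it reads 2-fluorophenyl to phenyl. For the measured compounds named here, no measured pair in this set shows this same change, so there is no measured step to lean on.

The expectation for compound 4 is a step in this assay of a 1.3-fold lower number from compound 1 to compound 4 (0.12 log units; within the scatter), downward, possibly still within the scatter. Compound 4 is thus estimated at 0.45 h, with a range from 0.2 h to 1 h.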

Compound 4, half-life: 0.737 h
The estimate for compound 4 lay 1.6-fold (0.21 log units) below the measured number, and the stated range covers the measured number.
By their numbers in this assay, from the lowest: compound 3; then compounds 1, 4 and 2 (each within the scatter of the next, the first and the last beyond it).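

In this assay, for the compounds shown here, going from 2-fluorophenyl to phenyl gives a 1.2-fold higher number from compound 1 to compound 4 (0.10 log units; within the scatter) and this is the first comparison in the set in which only one place differs. On this aromatic carbon, ortho to a large group, the fluoro can therefore be replaced by hydrogen without a difference that this read-out can separate from the ordinary spread of repeated measurements. Nothing available here explains why the two compounds read alike.

Still open, from the compounds shown here alone, is whether a larger group on this same carbon, such as a methoxy, an amine or a carboxylic acid, would shift the half-life beyond that spread. The role of the phenyl ring itself also stays unsettled: compound 3 lacks it but also differs in the chain on the far end, so that pair cannot decide the question.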